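Isopropyl in place of propyl: compound 3 expected to stay inactive

This account rests on a few compounds, and the source may have more. Where it says the series, first, only, none or still open, it means among the compounds named here.

Compound 1 `CC[C@H](CO)Nc1nc(N(C)Cc2ccccc2)c2ncn(C(C)C)c2n1`: in a functional assay on tsA201 cells for agonist activity at Voltage-dependent N-type calcium channel subunit alpha-1B (Homo sapiens), read by patch clamp (on this read-out higher numbers stand for an effect only at larger amounts of compound and lower numbers for an effect already at smaller amounts), compound 1 gives > 1000000 nM, a limit of the assay.
Compound 2 `CCCn1cnc2c(NCC3CC3)nc(N[C@H](CC)CO)nc21`: in this assay compound 2 gives > 100000 nM, also a limit of the assay.

Compound 2 therefore stands only at a limit, namely (the limit of > 100000 nM in this assay, at which 1 of the 2 values shown sits). Compound 1 sits at a different one, (the limit of > 1000000 nM in this assay, at which 1 of the 2 values shown sits). For the measured compounds named here, the two values show only that neither compound produced an effect within the tested range of this assay, and no measured step joins them.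

Compound 3 `CC[C@H](CO)Nc1nc(NCC2CC2)c2ncn(C(C)C)c2n1` is built from compound 2 by isopropyl in place of propyl on an aromatic nitrogen. Going by the values given here, with no measured step of this kind to lean on, and compound 2 itself showing no effect, the change is expected to bring no step beyond the scatter, that is a number no higher from compound 2 to compound 3 (the limit leaves the size open). Compound 3 is thus estimated to give about 100000 nM in this assay, within 30000 nM to 1000000 nM, most likely again reported only as a limit.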

Compound 3, half-maximal effective concentration: > 100000 nM
Compound 3 ended at the assay's limit; the forecaster's own chance of this, stated with the estimate: 85%; the middle value sits exactly at the limit.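

In this assay compound 3 gives > 100000 nM, a limit of the assay. For the compounds shown here, compound 1 and compound 2 also stand at limits, so no step from either one to compound 3 can be read. The compounds shown leave open whether any of them has an effect on this read-out, and how far apart they lie.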